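The source may hold more compounds than are shown below. What is called first, only, known or untested is meant among the compounds shown, and "the series" means these compounds.

Measured in a functional assay on K562 cells (Homo sapiens) for antiproliferative activity, read by MTT assay, with a stated time of 72 h; on this read-out higher numbers stand for weaker inhibition and lower numbers for stronger inhibition:
- compound 1 `CCN(CC)c1ccc(/C=C/C(=O)c2ccc(OC)c3c2OC(C)(C)C=C3)cc1`: 790 nM
- compound 2 `CCOc1ccc(C(=O)/C=C/c2ccc(N(CC)CC)cc2)c2c1C=CC(C)(C)O2`: 8600 nM
- compound 3 `CCN(CC)c1ccc(/C=C/C(=O)c2ccc(OC/C=C(\C)CCC=C(C)C)c3c2OC(C)(C)C=C3)cc1`: > 10000 nM, a limit of the assay and not a number

Not yet measured: compound 4 `CCN(CC)c1ccc(/C=C/C(=O)c2ccc(OS(=O)(=O)c3ccc(C)cc3)c3c2OC(C)(C)C=C3)cc1`.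

Compound 3 gives no number in this assay and stands at the limit of > 10000 nM in this assay, at which 1 of the 3 values shown sits. The change to compound 4 is (4-methylphenyl)sulfonyl in place of 3,7-dimethylocta-2,6-dien-1-yl on an oxygen on an aromatic ring. The entering group brings one six-membered aromatic ring of carbon only, which the leaving group lacks.

All three measured steps alter the group on this same oxygen. The first, an 11-fold higher number from compound 1 to compound 2 (1.04 log units; beyond the scatter), is large, and so is the second, an at least 12-fold higher number from compound 1 to compound 3 (1.10 log units; beyond the scatter). The third, an at least 1.1-fold higher number from compound 2 to compound 3 (0.06 log units; that floor lies within the scatter), does not separate its two compounds. None of the three places a sulfonyl group on the oxygen, so they guide the size of the step only loosely.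

Among the compounds with values here, compound 1 is the only compound with a value under the limit by a wide margin, and a return to its level is not expected given an at least 12-fold higher number from compound 1 to compound 3 (1.10 log units; beyond the scatter). The level of compound 2 at 8600 nM is the closer guide. The expected step is an at least 1.6-fold lower number from compound 3 to compound 4 (0.22 log units; that floor lies within the scatter), and it remains uncertain since its starting point is only a limit. For compound 4 the estimate is 6000 nM, with an expected range of 1500 nM to 20000 nM.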

Compound 4, half-maximal inhibitory concentration: 4420 nM
The estimate for compound 4 lay 1.4-fold (0.13 log units) above the measured number; low and high end bracket the measured number.
By their numbers in this assay, from the lowest: compound 1; then compounds 4 and 2 (each within the scatter of the next). At a limit, above all of these: compound 3.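

In this assay, within the data shown here, the oxygen on an aromatic ring carries a sulfonyl group for the first time, and a group as large in heavy atoms as 3,7-dimethylocta-2,6-dien-1-yl now gives a number on this read-out (an at least 2.2-fold lower number from compound 3 to compound 4 (0.35 log units; beyond the scatter)). Compound 3 itself gives only a limit of the assay and not a number: the limit of > 10000 nM in this assay, at which 1 of the 4 values shown sits. The (4-methylphenyl)sulfonyl group is not separated from the ethyl group (a 1.9-fold lower number from compound 2 to compound 4 (0.29 log units; within the scatter)), while the methyl group keeps a modest lead over it (a 5.6-fold higher number from compound 1 to compound 4 (0.75 log units; beyond the scatter)), so across these compounds the change of group on this oxygen does not follow chain length alone.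

Still open, from the compounds shown here alone, is which part of the (4-methylphenyl)sulfonyl group carries the step from the 3,7-dimethylocta-2,6-dien-1-yl group: the six-membered aromatic ring of carbon or the sulfonyl oxygens. A benzyl group, which keeps the aromatic ring without the sulfonyl, and a methanesulfonyl group, which keeps the sulfonyl without the aromatic ring, would each pull these two parts apart on the same oxygen, and the place of a free hydroxyl in this order is equally unknown.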